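Pyridyl swap on the methoxyethyl enol ether series

The compounds below may be only part of what the source reports. "The series", "measured", "known", "first", "only" and "open" are said of these compounds alone.

Compound 2 `CCO/C(O)=C1\C(C)=NC(C)=C([N+](=O)[O-])C1c1cccnc1` serves as the reference point. In a functional assay (cardiac atrium) for agonist activity, with Cavia porcellus as the target (a higher number here means that more compound is needed for the effect, a lower number that less compound is needed), compound 2 gives 8840 nM. Compound 1 `CCO/C(O)=C1\C(C)=NC(C)=C([N+](=O)[O-])C1c1ccccn1` carries pyridin-2-yl in place of pyridin-3-yl on a saturated ring carbon; in this assay compound 1 gives 22800 nM, a step of a 2.6-fold higher number from compound 2 to compound 1 (0.41 log units; beyond the scatter). Compound 3 `COCCO/C(O)=C1\C(C)=NC(C)=C([N+](=O)[O-])C1c1cccnc1` carries methoxy in place of hydrogen on a saturated chain carbon, two bonds along the chain from an oxygen on an unsaturated carbon; in this assay compound 3 gives 49400 nM, a step of a 5.6-fold higher number from compound 2 to compound 3 (0.75 log units; beyond the scatter). Of the three measured compounds, compound 3 shows the highest number, and its gaps to compound 1 and compound 2 are both beyond the scatter.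

Compound 4 `COCCO/C(O)=C1\C(C)=NC(C)=C([N+](=O)[O-])C1c1ccccn1` is not yet measured in this assay. It differs from compound 3 by pyridin-2-yl in place of pyridin-3-yl on a saturated ring carbon. This is the same change as from compound 2 to compound 1: the descriptions of the place agree word for word. The two cores on which the change is made differ as already told for compound 3 against compound 2, namely by the methoxy that enters on the ethoxy chain.

The change occurs twice among these compounds, and only one instance is measured, so the expectation rests on a single step. Among the measured compounds shown here, from compound 3 to compound 4 a step of a 2.3-fold higher number from compound 3 to compound 4 (0.37 log units; beyond the scatter) is expected, set beside a 2.6-fold higher number from compound 2 to compound 1 (0.41 log units; beyond the scatter), because the one measured instance of this change is a 2.6-fold higher number from compound 2 to compound 1 (0.41 log units; beyond the scatter). Whether the change behaves alike on the core of compound 3 is not known from these compounds, so the range is kept wide. For compound 4 in this assay a value of 115000 nM is estimated, with a lower end of 45000 nM and an upper end of 300000 nM.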

Compound 4, half-maximal effective concentration: 9700 nM
Estimate against measurement, compound 4: 12-fold (1.07 log units) above; measured number below the stated range.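

In this assay, the exchange of pyridin-3-yl for pyridin-2-yl on the saturated ring carbon does not carry over from the core of compound 2 to the core of compound 3; here it gives a 5.1-fold lower number from compound 3 to compound 4 (0.71 log units; beyond the scatter), opposite in direction to the earlier step: the same change on two cores in this assay, a 2.6-fold higher number (0.41 log units; beyond the scatter) from compound 2 to compound 1 and a 5.1-fold lower number (0.71 log units; beyond the scatter) from compound 3 to compound 4, 13-fold (1.12 log units) apart, beyond the scatter of two such steps

The methoxy on the chain is likewise tied to the aromatic ring it is paired with, since on the pyridin-2-yl compounds it gives a 2.4-fold lower number from compound 1 to compound 4 (0.37 log units; beyond the scatter), opposite in direction to its step on the pyridin-3-yl compounds: the same change on two cores in this assay, a 5.6-fold higher number (0.75 log units; beyond the scatter) from compound 2 to compound 3 and a 2.4-fold lower number (0.37 log units; beyond the scatter) from compound 1 to compound 4, 13-fold (1.12 log units) apart, beyond the scatter of two such steps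

Among the compounds shown here, these four compounds show that the two changes do not act independently in this set, but they form a single square with only two instances of each change, so they do not show why the direction reverses or how the change would behave on any further core.

The compounds shown leave open how a pyridin-4-yl or a plain phenyl on the saturated ring carbon would read on the ethoxy and methoxyethyl cores. They also leave open whether a longer chain, such as an ethoxyethyl group, or a terminal amine on the chain would follow the pattern of the pyridin-3-yl pair or that of the pyridin-2-yl pair.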